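Pyridazinone amides: aryl swap on the ring nitrogen

A few compounds are considered here, and "the series" means these few. Any claim that something is new, unique, unknown or untested is made for them only; others in the source may bear on it.

Compound 1 `Cc1cc(=O)n(-c2ccccc2C(F)(F)F)nc1C(=O)Nc1ccc(Oc2ncnc3ccsc23)cc1` gives 5550 nM in a functional assay on MCF7 cells (Homo sapiens) for cytotoxicity, read by MTT assay, with a stated time of 72 h; on this read-out lower numbers stand for stronger inhibition and higher numbers for weaker inhibition.
Compound 2 `Cc1cc(=O)n(-c2ccccc2C(F)(F)F)nc1C(=O)Nc1ccc(Oc2ncnc3sccc23)cc1` gives > 40000 nM in this assay, a limit of the assay rather than a number.

Compound 2 thus stands at the top of the numbers shown: its value is a limit, as recorded in the limit of > 40000 nM in this assay, at which 1 of the 2 values shown sits. Within the data shown here, the one measured step, an at least 7.2-fold higher number from compound 1 to compound 2 (0.85 log units; beyond the scatter), concerns the group on the oxygen on an aromatic ring and leaves the aryl on the ring nitrogen untouched, so it does not bear on the change considered here.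

Compound 3 `Cc1cc(=O)n(-c2cccc(F)c2)nc1C(=O)Nc1ccc(Oc2ncnc3sccc23)cc1` differs from compound 2 by 3-fluorophenyl in place of 2-(trifluoromethyl)phenyl on an aromatic nitrogen. Among the measured compounds shown here, no measured step touches this position, so the data give no basis for expecting a shift in this assay beyond the scatter in either direction. Compound 3 is therefore estimated at 40000 nM, with a range from 10000 nM to 100000 nM. That estimate means a number no higher from compound 2 to compound 3 (the limit leaves the size open), and a limit rather than a number is expected as the likelier outcome for compound 3.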

Compound 3, half-maximal inhibitory concentration: 27200 nM
For compound 3 the middle estimate is 1.5-fold (0.17 log units) above the measured one, within the range that was stated.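

Among these compounds, this is the first reading on the aryl at the aromatic nitrogen: in this assay, 3-fluorophenyl in place of 2-(trifluoromethyl)phenyl gives an at least 1.4-fold lower number from compound 2 to compound 3 (0.16 log units; that floor lies within the scatter). With this aryl, compound 3 gives a number, 27200 nM, so the change brings the value within the measurable range, but the step shows no gain beyond the scatter. The true size of the step stays open because compound 2 is held only by a limit, not a number: the limit of > 40000 nM in this assay, at which 1 of the 3 values shown sits.

Going by these compounds, whether the same aryl swap would shift the value when the oxygen carries the group of compound 1 remains open. Also open, on these data alone, is how an unsubstituted phenyl, or a phenyl bearing a methoxy group or an amine, would read on this nitrogen.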